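The source may report more compounds than this note shows. Statements on the series, on what has been measured and on what is new or still open speak of the compounds shown alone.

Working notes on the series. Compound 1 `O=C1c2ccccc2S(=O)(=O)N1CCCCN1CCN(c2cccc(C(F)(F)F)c2)CC1` stands in an assay on isolated protein for binding affinity to D(4) dopamine receptor (Homo sapiens) (a higher number here means a weaker inhibitor, a lower number a stronger inhibitor), only as a limit: compound 1 gives > 5000 nM, which is a limit of the assay rather than a number (the limit of > 5000 nM in this assay, at which 1 of the 2 values shown sits). Compound 2 `O=C1c2ccccc2S(=O)(=O)N1CCCCCCN1CCN(c2ccccc2)CC1` carries no result in this assay, where compound 2 gives "not determined" (no result reported). Compound 3 `O=C1c2ccccc2S(=O)(=O)N1CCCCN1CCN(c2ccccc2)CC1` differs from compound 1 by hydrogen in place of trifluoromethyl on an aromatic carbon. Within the data shown here, no measured step covers this change, so its size and direction remain open; from a limit, only a move toward stronger inhibition could register. Compound 3 is expected at 1500 nM, between 150 nM and 8000 nM. The expected step is an at least 3.3-fold lower number from compound 1 to compound 3 (0.52 log units; beyond the scatter).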

Compound 3, inhibition constant: 136 nM
Beside the measured number, compound 3's estimate is 11-fold (1.04 log units) above it; the measured number lies below the stated range.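

Hydrogen in place of trifluoromethyl on this aromatic carbon gives an at least 36-fold lower number from compound 1 to compound 3 (1.56 log units; beyond the scatter) in this assay, the first sign that this position matters for the series. Going by these compounds, the step is a minimum, and its true size remains unknown. Compound 1 stands only at a limit of the assay, not at a number: the limit of > 5000 nM in this assay, at which 1 of the 3 values shown sits.

On these data alone, the comparison covers only hydrogen and trifluoromethyl at this place, so the outcome with a smaller group such as fluorine or methoxy stays open. How a longer chain acts on this core also remains unread.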